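Opening the Five-Membered Ring of Compound 2

The source may report more compounds than this note shows. Statements on the series, on what has been measured and on what is new or still open speak of the compounds shown alone.

Compound 1 `O=C(CCCCC1CCSS1)Nc1ccc([N+](=O)[O-])c(C(F)(F)F)c1` gives 5.04%
Compound 2 `O=C(CCCCC1CCSS1)Nc1cccc2ccccc12` gives 3.4%

In a functional assay on Bel-7402 cells (Homo sapiens) for inhibition, read by MTT assay, with a stated time of 24 h, tested at 0.1 ug/mL (a higher number here means more inhibition of growth at the concentration tested, a lower number less inhibition of growth), compound 2 gives 3.4%, within the usual scatter of compound 1 at 5.04%, so the two cannot be ranked. Compound 3 `O=C(CCCCC(S)CCS)Nc1cccc2ccccc12` has not yet been measured. Its structure differs from that of compound 2 as follows: a group of 5 heavy atoms (3 carbon, 2 sulfur; no ring) in place of a group of 5 heavy atoms (3 carbon, 2 sulfur; one five-membered non-aromatic ring with 2 hetero atoms), on a saturated chain carbon, four bonds along the chain from a carbonyl carbon. The ring is replaced by the open 1,3-disulfanylpropyl group, on a saturated chain carbon, four bonds along the chain from a carbonyl carbon. For the measured compounds named here, no measured pair shows what such a change does, so no change beyond the scatter is expected. The expected result is a number 1.6 percentage points higher from compound 2 to compound 3 (within the scatter). For compound 3 the estimated value is 5%, with an expected range of 0% to 15%.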

Compound 3, percent growth inhibition at one concentration: "not active" (no number reported)
No number was reported for compound 3, and the estimate cannot be compared.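

For the compounds shown here, compound 3 was reported as not active, without a number, so no step from compound 2 to compound 3 can be read, and no evidence bears on this result. On these data alone, whether opening the ring changes growth inhibition remains open.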